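Butyl to isobutyl on compound 1: working notes

The source may hold more compounds than are shown below. What is called first, only, known or untested is meant among the compounds shown, and "the series" means these compounds.

compound 1 `CCCCc1ccc(-c2c(C)[nH]c(=O)n2C)cc1` gives 10700 nM in a functional assay on brain (Rattus norvegicus, strain Wistar) for inhibition; on this read-out lower numbers stand for stronger inhibition and higher numbers for weaker inhibition
compound 2 `CCCCc1ccc(-c2c(C)[nH]c(=O)n2C2CCCCC2)cc1` gives 27100 nM in this assay
compound 3 `CCCCc1ccc(-c2c(C)[nH]c(=O)n2Cc2ccccc2)cc1` gives 12400 nM in this assay

Compound 1 shares the low end of these numbers with compound 3: a 1.2-fold higher number from compound 1 to compound 3 (0.06 log units; within the scatter) separates the two, while a 2.5-fold higher number from compound 1 to compound 2 (0.40 log units; beyond the scatter) sets compound 2 apart.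

Compound 4 `Cc1[nH]c(=O)n(C)c1-c1ccc(CC(C)C)cc1` has the same atoms as compound 1, joined differently: isopropyl in place of propyl on a saturated chain carbon bound to an aromatic carbon and the change reads, cut one bond further out, as butyl to isobutyl.

All measured steps concern the group on the aromatic nitrogen, and none touches the chain on the aromatic carbon, so the data give no direct size for this change. The third, a 2.2-fold lower number from compound 2 to compound 3 (0.34 log units; beyond the scatter), is also modest. Taking a 2.5-fold higher number from compound 1 to compound 2 (0.40 log units; beyond the scatter) as the largest step seen, only a small move towards a higher number is expected in this assay and none beyond the scatter. The estimated step is a 1.2-fold higher number from compound 1 to compound 4 (0.08 log units; within the scatter) and remains an expectation. The estimate for compound 4 is 13000 nM with an expected range from 6000 nM to 30000 nM pending measurement.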

Compound 4, half-maximal inhibitory concentration: 7800 nM
Compound 4: the middle estimate sits 1.7-fold (0.22 log units) above what was measured, within the range that was stated.
By their numbers in this assay, from the lowest: compounds 4, 1 and 3 (each within the scatter of the next); then compound 2.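

The chain on the aromatic carbon now has a measured step of its own: in this assay, a 1.4-fold lower number from compound 1 to compound 4 (0.14 log units; within the scatter) for isopropyl in place of propyl on a saturated chain carbon bound to an aromatic carbon. At this place, then, rearranging the chain from butyl to isobutyl, with the same atoms joined differently, produces no change beyond the scatter, so compound 1 and compound 4 cannot be ordered on this read-out. No measurement shown accounts for this result.

The compounds shown leave open whether a longer chain such as hexyl, or a chain carrying an amine or a carboxylic acid, would give a step beyond the scatter here. Also open, on these data alone, is whether isobutyl gives a similar step with cyclohexyl or benzyl on the aromatic nitrogen.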